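Methyl added to the thiadiazole of compound 3

The compounds below may be only part of what the source reports. "The series", "measured", "known", "first", "only" and "open" are said of these compounds alone.

Going by the values given here, in an ADME assay for permeability, using PAMPA, with a stated time of 4 h, at pH 7.4, tested at 5 uM (on this read-out higher numbers stand for higher permeability and lower numbers for lower permeability), compound 3 (`Cn1nccc1[C@H]1CCC[C@@H]1Oc1cc(F)c(S(=O)(=O)Nc2ncns2)cc1F`) gives 0.3 10^-6 cm/s, the lowest number measured so far, while compound 1 (`Cn1nccc1[C@H]1CCCC[C@@H]1Oc1cc(F)c(S(=O)(=O)Nc2ccncn2)cc1F`) gives 5 10^-6 cm/s. Compound 2 (`Cn1nccc1[C@H]1CCC[C@@H]1Oc1cc(F)c(S(=O)(=O)Nc2nccs2)cc1F`) reads > 50 10^-6 cm/s, which is a limit of the assay.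

Compound 4 (`Cc1nsc(NS(=O)(=O)c2cc(F)c(O[C@H]3CCC[C@@H]3c3ccnn3C)cc2F)n1`) differs from compound 3 by methyl in place of hydrogen on an aromatic carbon, between two ring nitrogen atoms. Among the compounds with values here, the only measured step at this ring, an at least 160-fold lower number from compound 2 to compound 3 (2.22 log units; beyond the scatter), is large and beyond the scatter, but it exchanges one ring for another and adds no methyl, so it is a loose guide. With compound 3 at 0.3 10^-6 cm/s, a moderate rise in this assay is expected. The expected change is a 3.3-fold higher number from compound 3 to compound 4 (0.52 log units; beyond the scatter). For compound 4 the estimate is 1 10^-6 cm/s, with an expected range of 0.3 10^-6 cm/s to 4 10^-6 cm/s.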

Compound 4, apparent permeability: 12.6 10^-6 cm/s
The estimate for compound 4 lay 13-fold (1.10 log units) below the measured number; measured number outside the range, above it.
By their numbers in this assay, from the lowest: compound 3; then compound 1; then compound 4. At a limit, above all of these: compound 2.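

In this assay, the aromatic carbon between two ring nitrogen atoms of the thiadiazole proves a highly sensitive position: methyl in place of hydrogen alone gives a 42-fold higher number from compound 3 to compound 4 (1.62 log units; beyond the scatter). This single change recovers much of the ground lost on the ring exchange, but a gap to the thiazole remains: an at least 3.9-fold lower number from compound 2 to compound 4 (0.59 log units; beyond the scatter). Compound 2 gives > 50 10^-6 cm/s, which is a limit.

Still open, as far as these compounds go, is whether ethyl, methoxy or an amine on this carbon would read like methyl. Also open, from the compounds shown here alone, is whether methyl alone drives so large a step on other rings.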